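Methyl for chloro at the aryl ring of compound 1

The compounds below may be only part of what the source reports. "The series", "measured", "known", "first", "only" and "open" are said of these compounds alone.

Measured so far:
compound 1, `C=CCn1c(=O)/c(=C\c2cccc(Cl)c2)[nH]c(=O)/c1=C\c1ccccc1OC`: 5200 nM in a functional assay on MCF7 cells (Homo sapiens) for cytotoxicity, read by CCK-8 assay, with a stated time of 72 h; a lower number here means a stronger inhibitor, a higher number a weaker inhibitor
compound 2, `C=CCn1c(=O)/c(=C\c2ccccc2C(F)(F)F)[nH]c(=O)/c1=C\c1ccccc1OC`: 6500 nM in this assay
compound 3, `C=CCn1c(=O)/c(=C\c2ccc(F)c(Br)c2)[nH]c(=O)/c1=C\c1ccccc1OC`: reported as "not active" (no number reported) in this assay, with no single number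

Compound 1 holds the lowest of the two numbers; the nearest is compound 2, and the step of a 1.3-fold higher number from compound 1 to compound 2 (0.10 log units; within the scatter) lies within the scatter. Compound 3 gives no number at all.

Compound 4, `C=CCn1c(=O)/c(=C\c2cccc(C)c2)[nH]c(=O)/c1=C\c1ccccc1OC`, is not yet measured. It differs from compound 1 by methyl in place of chloro on an aromatic carbon. Going by the values given here, the only measured step, a 1.3-fold higher number from compound 1 to compound 2 (0.10 log units; within the scatter), alters the same ring but by a different group, and stayed within the scatter; nothing bears directly on methyl for chloro. A step of a 1.3-fold higher number from compound 1 to compound 4 (0.10 log units; within the scatter) is therefore expected, within the scatter. Compound 4 is estimated at 6500 nM, with a range from 2600 nM to 16000 nM.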

Compound 4, half-maximal inhibitory concentration: 20700 nM
Compound 4: middle estimate off by 3.2-fold (0.50 log units), on the low side; measured number above the stated range.
By their numbers in this assay, from the lowest: compounds 1 and 2 (each within the scatter of the next); then compound 4.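

In this assay, this position now shows a step beyond the scatter: a 4.0-fold higher number from compound 1 to compound 4 (0.60 log units; beyond the scatter) for methyl in place of chloro, on an aromatic carbon meta to a large group. Going by these compounds alone, the only earlier numerical step stayed within the scatter, whereas a 3.2-fold higher number from compound 2 to compound 4 (0.50 log units; beyond the scatter) also sets 3-methylphenyl apart from 2-(trifluoromethyl)phenyl. Nothing available gives a reason for these differences.

Going by these compounds, whether a nitrile or an amine at this place would read closer to chloro or to methyl remains open. Compound 3 adds no number for comparison.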